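This account rests on a few compounds, and the source may have more. Where it says the series, first, only, none or still open, it means among the compounds named here.

Measured so far in this series:

compound 1 `Cc1ccccc1C(=O)OC(CCN(C)C)c1ccc(Cl)cc1` — 1700 nM
compound 2 `Cc1cccc(C(=O)OC(CCN(C)C)c2ccc(Cl)cc2)c1C` — 1150 nM
compound 3 `Cc1ccc(C)c(C(=O)OC(CCN(C)C)c2ccc(Cl)cc2)c1` — 1860 nM

In an assay on NIH3T3 cells with Urotensin-2 receptor (Homo sapiens) as the target (on this read-out lower numbers stand for an effect already at smaller amounts and higher numbers for an effect only at larger amounts of compound), compound 3 sits within the scatter of both other compounds: a 1.1-fold higher number from compound 1 to compound 3 (0.04 log units; within the scatter) and a 1.6-fold higher number from compound 2 to compound 3 (0.21 log units; within the scatter). No ordering among the three can be read from these numbers.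

Compound 4 `Cc1cc(C)c(C(=O)OC(CCN(C)C)c2ccc(Cl)cc2)cc1C` differs from compound 3 by methyl in place of hydrogen on an aromatic carbon. Going by the values given here, two measured steps bear on this change, each also a methyl in place of hydrogen on an aromatic carbon of the same ester-side ring: a 1.5-fold lower number from compound 1 to compound 2 (0.17 log units; within the scatter) and a 1.1-fold higher number from compound 1 to compound 3 (0.04 log units; within the scatter). Among the compounds with values here, neither of these leaves the scatter, and there is no measured step in which such a methyl moved the number by more than the scatter. Accordingly the step to compound 4 is expected to be flat, a 1.0-fold lower number from compound 3 to compound 4 (0.01 log units; within the scatter), with a wide range because only two precedents exist.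

For compound 4 the expected value in this assay is 1800 nM, with a range of 900 nM to 3600 nM.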

Compound 4, half-maximal effective concentration: 468 nM
For compound 4 the middle estimate is 3.8-fold (0.59 log units) above the measured one, outside the stated range (below it).
By their numbers in this assay, from the lowest: compound 4; then compounds 2, 1 and 3 (each within the scatter of the next).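

In this assay, methyl in place of hydrogen on an aromatic carbon now gives a step beyond the scatter, a 4.0-fold lower number from compound 3 to compound 4 (0.60 log units; beyond the scatter), at the place ortho to a methyl group, meta to a methyl group and para to a large group. The earlier compounds shown here, all within the scatter of one another, gave no sign that a methyl on this ring could matter. The change also has no single size across the series: the same change on two cores in this assay, a 1.5-fold lower number (0.17 log units; within the scatter) from compound 1 to compound 2 and a 4.0-fold lower number (0.60 log units; beyond the scatter) from compound 3 to compound 4, 2.7-fold (0.43 log units) apart, beyond the scatter of two such steps.

The compounds shown leave open whether this step depends on the two methyl groups already on the ring or would also appear on the core of compound 1. As far as these compounds go, it is also open whether an ethyl, a methoxy, a chlorine or an amine at this place would give a similar step.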